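The source may hold more compounds than are shown below. What is called first, only, known or untested is meant among the compounds shown, and "the series" means these compounds.

Three thiourea derivatives built on a shared core have been examined in a functional assay on T98G cells (Homo sapiens) for inhibition, read by MTT assay, with a stated time of 72 h; a higher number here means a weaker inhibitor, a lower number a stronger inhibitor. Compound 1 `COc1cccc(NC(=S)NC2CC(C)(C)Oc3ccc(Br)cc32)c1` gives 87000 nM. Compound 2 `O=[N+]([O-])c1cccc(NC(=S)NC2CCOc3ccc(Cl)cc32)c1` gives 10000 nM, and compound 3 `CC1(C)CC(NC(=S)Nc2ccc([N+](=O)[O-])cc2)c2cc(Br)ccc2O1` gives 5000 nM. Among these three, compound 1 stands highest, and its gap to both compound 2 and compound 3 lies beyond the usual scatter, so it is the weakest inhibitor of the measured set in this assay.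

A fourth compound, compound 4 `CC1(C)CC(NC(=S)NCc2ccccc2)c2cc(Br)ccc2O1`, has not yet been measured. It differs from compound 1 in one place: benzyl in place of 3-methoxyphenyl on an amide-type nitrogen. For the measured compounds named here, no pair of measured compounds differs by this same change, so there is no directly comparable step to draw on; the nearest information is that compound 2 and compound 3, which carry nitrophenyl groups instead, give lower numbers than compound 1.

Going by the values given here, with no matching step in hand, compound 4 is expected to stay near compound 1 in this assay, with a step from compound 1 to compound 4 of a 1.5-fold lower number from compound 1 to compound 4 (0.16 log units; within the scatter) that may fall within the scatter. The estimated value for compound 4 is 60000 nM, with a range from 15000 nM to 200000 nM.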

Compound 4, half-maximal inhibitory concentration: 54000 nM
Beside the measured number, compound 4's estimate is 1.1-fold (0.05 log units) above it, and the stated range covers the measured number.
By their numbers in this assay, from the lowest: compounds 3 and 2 (each within the scatter of the next); then compounds 4 and 1 (each within the scatter of the next).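

In this assay, putting benzyl in place of 3-methoxyphenyl on the amide-type nitrogen, whose other neighbour is the thiocarbonyl carbon, gives a 1.6-fold lower number from compound 1 to compound 4 (0.21 log units; within the scatter), so the assay does not separate the two compounds. For the compounds shown here, this is the first single-place change in the set, and it shows that this position can take a different group without a step beyond the scatter: the ring stays a six-membered aromatic ring of carbon only, while the hydrogen-bond acceptor of 3-methoxyphenyl is absent from benzyl. No measurement here gives a reason for this result.

The change also alters two things at once, removing the methoxy group and altering how the ring is attached to the nitrogen, so a plain phenyl group would be needed to tell these two parts apart. Also open, going by these compounds, is whether a longer chain such as phenethyl, or a benzyl group carrying a carboxylic acid or an amine, would stay within the scatter of compound 1 or give a step beyond it.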